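Hydroxyphenyl Variant in a Triazole-Linked Lactam Series

The source may report more compounds than this note shows. Statements on the series, on what has been measured and on what is new or still open speak of the compounds shown alone.

Compound 1, `Cc1ccc(-n2cc(CN3C(=O)C[C@@H]4CC[C@@]3(C)C4(C)C)nn2)cc1`: in a functional assay on PANC-1 cells (Homo sapiens) for inhibition, read by MTT assay, with a stated time of 24 h (on this read-out lower numbers stand for stronger inhibition and higher numbers for weaker inhibition), compound 1 gives 270 nM.
Compound 2, `CC1(C)[C@H]2CC[C@]1(C)N(Cc1cn(-c3ccccc3C#N)nn1)C(=O)C2`: in this assay compound 2 gives 240 nM.
Compound 3, `CC1(C)[C@H]2CC[C@]1(C)N(Cc1cn(-c3cccc(Br)c3)nn1)C(=O)C2`: in this assay compound 3 gives 90 nM.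

Compound 2 stands second highest of the three numbers. Its nearest neighbour is compound 1: the step of a 1.1-fold lower number from compound 1 to compound 2 (0.05 log units; within the scatter) lies within the scatter, so the two cannot be ordered. Its furthest neighbour is compound 3, reached by a 2.7-fold lower number from compound 2 to compound 3 (0.43 log units; beyond the scatter), a modest change that does exceed the scatter.

Compound 4, `CC1(C)[C@H]2CC[C@]1(C)N(Cc1cn(-c3ccc(O)cc3)nn1)C(=O)C2`, differs from compound 2 by 4-hydroxyphenyl in place of 2-cyanophenyl on an aromatic nitrogen. Both measured steps that leave compound 2 change the group on the same aromatic nitrogen and are therefore the ones that bear on this change: a 1.1-fold lower number from compound 1 to compound 2 (0.05 log units; within the scatter) is within the scatter, while a 2.7-fold lower number from compound 2 to compound 3 (0.43 log units; beyond the scatter) is modest. Within the data shown here, neither involves a 4-hydroxyphenyl, so no direct precedent exists. Compound 1, which carries a 4-methylphenyl on an aromatic nitrogen, sits within the scatter of compound 2, and that is the closest guide. The step of a 1.0-fold higher number from compound 2 to compound 4 (0.02 log units; within the scatter) is therefore expected to be none beyond the scatter. Compound 4 is estimated at 250 nM, with a range from 100 nM to 600 nM.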

Compound 4, half-maximal inhibitory concentration: 100 nM
Estimate against measurement, compound 4: 2.5-fold (0.40 log units) above, and the stated range covers the measured number.
By their numbers in this assay, from the lowest: compounds 3 and 4 (each within the scatter of the next); then compounds 2 and 1 (each within the scatter of the next).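

In this assay, among these compounds, the exchange of hydroxy for methyl on an aromatic carbon gives a 2.7-fold lower number from compound 1 to compound 4 (0.43 log units; beyond the scatter), the first step in this set that alters a single substituent on the phenyl group while keeping the rest of compound 1 unchanged, and it shows that this one change is enough to pass beyond the scatter. The comparison with the nitrile-bearing group points the same way, with a 2.4-fold lower number from compound 2 to compound 4 (0.38 log units; beyond the scatter), whereas a 1.1-fold higher number from compound 3 to compound 4 (0.05 log units; within the scatter) leaves 4-hydroxyphenyl and 3-bromophenyl unordered, so the aromatic nitrogen of the five-membered ring now has two quite different aryl groups that cannot be separated, both set apart from 4-methylphenyl and 2-cyanophenyl. Nothing in the available data accounts for these steps.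

The compounds shown leave open whether a methoxy, an amine or a carboxylic acid in place of the hydroxy on 4-hydroxyphenyl would keep the number at this level. They also leave open how an unsubstituted phenyl group on the same nitrogen would compare with these four aryl groups.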